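A few compounds are considered here, and "the series" means these few. Any claim that something is new, unique, unknown or untested is made for them only; others in the source may bear on it.

Of the compounds shown here, three have been tested so far. Compound 1 `c1ccc(Cc2[nH]cnc3ncnc2-3)cc1` and compound 2 `Fc1ccc(Cc2[nH]cnc3ncnc2-3)cc1` share one core, while compound 3 `Cn1cnc2c(-c3ccccc3)ncnc21` is built from the same atoms joined in a different way; the difference between the core of compound 1 and the core of compound 3 is not broken down here. In an assay on isolated protein for inhibition of RAC-alpha serine/threonine-protein kinase (Homo sapiens), tested at 30 uM (a lower number here means less inhibition, a higher number more inhibition at the concentration tested (going by the name of the read-out)), compound 1 gives 0% and compound 2 gives 3%. Going a number 3 percentage points higher from compound 1 to compound 2 (within the scatter) means that the change fluoro in place of hydrogen on an aromatic carbon left the read-out essentially where it was. In this assay compound 3 gives 15%, the highest of the three numbers, standing beyond the scatter from both compound 2 and compound 1.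

Compound 4 `Cn1cnc2c(-c3ccc(F)cc3)ncnc21` has not yet been measured. For the measured compounds named here, it differs from compound 3 by fluoro in place of hydrogen on an aromatic carbon, which is the same change as the one from compound 1 to compound 2, made at a place described in the same words. The expectation for compound 4 in this assay is a step of a number 3 percentage points higher from compound 3 to compound 4 (within the scatter) from compound 3, a small movement within the scatter, because the same change earlier gave a number 3 percentage points higher from compound 1 to compound 2 (within the scatter) on the other core. Going by the values given here, only one earlier example exists, so this rests on a single pair. Compound 4 is therefore estimated at 18%, most likely somewhere between 5% and 32%.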

Compound 4, a percentage reported as inhibition, at one concentration (the size of the read-out at that concentration, not a potency): 0%
Estimate against measurement, compound 4: 18 percentage points above; measured number outside the range, below it.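

In this assay, putting fluoro in place of hydrogen on an aromatic carbon, para to a large group, gave a number 15 percentage points lower from compound 3 to compound 4 (beyond the scatter), so on this core the change was not neutral. Set beside the earlier pair, the same change did not carry over from one core to the other, and the step seen on one core could not be used as a forecast for the other: the same change on two cores in this assay, a number 3 percentage points higher (within the scatter) from compound 1 to compound 2 and a number 15 percentage points lower (beyond the scatter) from compound 3 to compound 4, 18 percentage points apart, beyond the scatter of two such steps. For the compounds shown here, this shows that, in these two pairs, the outcome of the change depended on which core carried it, but it does not show which feature of the two cores matters, why the steps differ, or how the change would behave on a third core, and since each core supplies only one pair and the read-out is a percentage at one concentration, it says nothing about potency.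

On these data alone, it remains open whether the drop on the core of compound 3 is particular to fluoro or would also appear with chloro, methyl, methoxy or an amine on the same aromatic carbon. Also open, as far as these compounds go, is whether a larger group there, such as a carboxylic acid or a longer chain, would raise the inhibition above that of compound 3 or leave it lower.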